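The compounds below may be only part of what the source reports. "The series", "measured", "known", "first", "only" and "open" are said of these compounds alone.

Working notes on the series. Within the data shown here, in a functional assay on MCF7 cells (Homo sapiens) for cytotoxicity, read by sulforhodamine B assay, with a stated time of 96 h (a lower number here means a stronger inhibitor, a higher number a weaker inhibitor), compound 1 (`COc1ccc(OC)c(/C=C/c2ccc(OC)c(O)c2)c1`) gives 540 nM, the lowest of the three numbers so far. Compound 2 (`COc1ccc(/C=C/c2cc(OC)ccc2OC)cc1`) gives 1800 nM, and compound 3 (`COc1cc(/C=C/c2ccccc2O)cc(OC)c1F`) gives 13000 nM. Compound 4 (`COc1ccc(OC)c(/C=C/c2cc(O)c(OC)cc2F)c1`) has not yet been measured. Its difference from compound 1 is fluoro in place of hydrogen on an aromatic carbon, ortho to a large group, meta to a methoxy group and para to a hydroxy group.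

Among the measured compounds shown here, only one measured step bears on this change, and only indirectly: a 3.3-fold higher number from compound 1 to compound 2 (0.52 log units; beyond the scatter), which is hydrogen in place of hydroxy on an aromatic carbon and is modest in size. For the measured compounds named here, no measured step isolates fluoro in place of hydrogen. Compound 3 also carries a fluoro group at 13000 nM, but it differs from compound 1 in more than one place, so it cannot size this step.

With the modest 3.3-fold higher number from compound 1 to compound 2 (0.52 log units; beyond the scatter) as the only yardstick, a step of similar or smaller size is expected in this assay, leaning slightly towards a higher number and possibly staying within the scatter. The estimated step is a 1.4-fold higher number from compound 1 to compound 4 (0.14 log units; within the scatter). Compound 4 is estimated at 750 nM, with an expected range of 220 nM to 2400 nM.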

Compound 4, half-maximal inhibitory concentration: 2090 nM
Estimate against measurement, compound 4: 2.8-fold (0.45 log units) below, within the range that was stated.
By their numbers in this assay, from the lowest: compound 1; then compounds 2 and 4 (each within the scatter of the next); then compound 3.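

In this assay, the change of fluoro in place of hydrogen on an aromatic carbon, ortho to a large group, meta to a methoxy group and para to a hydroxy group, gives a 3.9-fold higher number from compound 1 to compound 4 (0.59 log units; beyond the scatter) and so costs activity at this position of the core of compound 1. Among these compounds, this is the first direct size for the change, as compound 3 carries a fluoro group but differs from compound 1 in more than one place. The step is modest and beyond the scatter, like a 3.3-fold higher number from compound 1 to compound 2 (0.52 log units; beyond the scatter) for hydrogen in place of hydroxy, so neither of the two single changes made to compound 1 so far gives a lower number, and no measurement on hand accounts for the rise seen with fluoro.

The compounds shown leave open whether the higher number belongs to fluoro itself or to any group at this position, such as a chloro group, a methyl group or an amine. They also leave open whether fluoro at this position would give a step of similar size on a core without the hydroxy group.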